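The compounds below may be only part of what the source reports. "The series", "measured", "known", "first", "only" and "open" are said of these compounds alone.

Compound 1 (`c1ccc(-c2ccc(-c3ccc(-c4nc5ccccc5[nH]4)cc3)cc2)cc1`) is the starting point. Within the data shown here, in a functional assay on ZR-75-1 cells (Homo sapiens) for inhibition, read by sulforhodamine B assay (on this read-out higher numbers stand for weaker inhibition of growth and lower numbers for stronger inhibition of growth), compound 1 gives 100000 nM and holds the highest of the three numbers so far, which makes it the weakest growth inhibitor among them. Compound 2 (`Cc1ccc2[nH]c(-c3ccc(-c4ccc(-c5cccc(Cl)c5)cc4)cc3)nc2c1`) gives 3450 nM and compound 3 (`COc1ccc(-c2ccc(-c3ccc(-c4nc5cc(C)ccc5[nH]4)cc3)cc2)cc1OC`) gives 3100 nM on the same read-out. Both differ from compound 1 in more than one place, so their much lower numbers cannot be pinned on a single change.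

Compound 4 (`Fc1ccc(-c2ccc(-c3ccc(-c4nc5ccccc5[nH]4)cc3)cc2)cc1`) keeps the core of compound 1 and carries fluoro in place of hydrogen on an aromatic carbon, para to a large group (fluoro in place of hydrogen on an aromatic carbon). Among the measured compounds shown here, only one measured step comes close to this change: a 1.1-fold lower number from compound 2 to compound 3 (0.05 log units; within the scatter) stays within the scatter, but it swaps one substituted phenyl for another and does not show what replacing a hydrogen does. With so little to go on, a moderate move towards a lower number in this assay is expected, well short of the full gap to compound 2 and compound 3. The estimated change is a 5.0-fold lower number from compound 1 to compound 4 (0.70 log units; beyond the scatter) and it carries wide uncertainty. For compound 4 the expected value is 20000 nM with an estimated range from 4000 nM to 100000 nM as its limits.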

Compound 4, concentration for 50% growth inhibition: 100000 nM
Compound 4: the middle estimate sits 5.0-fold (0.70 log units) below what was measured, and the stated range covers the measured number.
By their numbers in this assay, from the lowest: compounds 3 and 2 (each within the scatter of the next); then compounds 1 and 4 (each within the scatter of the next).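

Going from phenyl to 4-fluorophenyl in this assay gives no change at the digits printed from compound 1 to compound 4 (within the scatter), and this is the first step here that changes a single place on the core of compound 1. At this position, on an aromatic carbon para to a large group, fluoro in place of hydrogen therefore leaves the number where it was, whereas the step between compounds 2 and 3 only swapped one substituted phenyl for another. No measurement at hand accounts for this result.

Going by these compounds, whether a larger group at the same position, such as an amine, a carboxylic acid or a longer chain, would move the number remains open. Also open, on these data alone, is whether fluoro would behave the same way on the methyl-bearing core of compounds 2 and 3.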